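Capping the acid: an ethyl ester on the amino-acid tail

The source may hold more compounds than are shown below. What is called first, only, known or untested is meant among the compounds shown, and "the series" means these compounds.

Measured so far:
compound 1, `COc1cc(-c2nc3ccccc3s2)ccc1OCC(=O)NNC(=O)CCl`, 2890 nM
compound 2, `CC[C@H](C)[C@H](NCC(=O)NNC(=O)COc1ccc(-c2nc3ccccc3s2)cc1OC)C(=O)O`, 3540 nM
compound 3, `CC[C@H](C)[C@@H](NCC(=O)NNC(=O)COc1ccc(-c2nc3ccccc3s2)cc1OC)C(=O)O`, 3990 nM

The three compounds share one core and differ only in the tail at the far end of the chain. In a functional assay on HepG2 cells (Homo sapiens) for inhibition, read by MTT assay, with a stated time of 3 days (a lower number here means a stronger inhibitor, a higher number a weaker inhibitor), compound 3 gives the highest of the three numbers, but its neighbours are very close: a 1.1-fold higher number from compound 2 to compound 3 (0.05 log units; within the scatter) and a 1.4-fold higher number from compound 1 to compound 3 (0.14 log units; within the scatter). The two closest compounds are mirror-image partners at one centre (the fact that compounds 2 and 3 differ only in the configuration as drawn), and that swap moves the number hardly at all.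

Compound 4, `CCOC(=O)[C@@H](NCC(=O)NNC(=O)COc1ccc(-c2nc3ccccc3s2)cc1OC)[C@@H](C)CC`, has not been measured. It differs from compound 3 in one place: 1-(ethoxycarbonyl)-2-methylbutyl in place of 1-carboxy-2-methylbutyl on an amine nitrogen. The carboxylic acid of compound 3 becomes an ethyl ester.

Among the measured compounds shown here, no measured step touches this exact change. The nearest guide is a 1.2-fold higher number from compound 1 to compound 2 (0.09 log units; within the scatter), where a small chloro group was exchanged for the whole 1-carboxy-2-methylbutyl amino tail without a shift beyond the scatter, and a 1.4-fold higher number from compound 1 to compound 3 (0.14 log units; within the scatter) says the same. The tail region therefore looks tolerant of change, and no step beyond the scatter is expected from compound 3 to compound 4.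

For compound 4 the expected step is a 1.1-fold lower number from compound 3 to compound 4 (0.06 log units; within the scatter), so the estimate in this assay is 3500 nM, with a likely range from 1500 nM to 8000 nM.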

Compound 4, half-maximal inhibitory concentration: 3460 nM
Estimate against measurement, compound 4: 1.0-fold (0.00 log units) above; the measured number falls inside the stated range.
By their numbers in this assay, from the lowest: compounds 1, 4, 2 and 3 (each within the scatter of the next).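

Capping the acid leaves the number in this assay in place. The cleanest reading is a 1.0-fold lower number from compound 2 to compound 4 (0.01 log units; within the scatter), where ethyl stands in place of hydrogen on an oxygen next to a carbonyl group, and a 1.2-fold lower number from compound 3 to compound 4 (0.06 log units; within the scatter) agrees with it. The earlier compounds shown here all carried either chloro or the free acid, whereas 1-(ethoxycarbonyl)-2-methylbutyl has 0 hydrogen-bond donors against 1 in 1-carboxy-2-methylbutyl, and this difference makes no mark beyond the scatter, just as a 1.2-fold higher number from compound 1 to compound 4 (0.08 log units; within the scatter) puts the ester tail level with chloro. The two acids can be read as one reference for the ester, since their numbers lie within the scatter of each other and a single difference separates them: the fact that compounds 2 and 3 differ only in the configuration as drawn.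

All four tails therefore give numbers within the scatter of one another, so the compounds shown do not reveal any tail that moves this assay at all. A primary amide in place of the ester, or a longer chain in place of the 2-methylbutyl part, would show whether this position can shift the number in either direction.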